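A few compounds are considered here, and "the series" means these few. Any claim that something is new, unique, unknown or untested is made for them only; others in the source may bear on it.

Of the compounds shown here, three on a shared core have been measured in a functional assay on HT cells (Homo sapiens) for antiproliferative activity, read by fluorescence, with a stated time of 72 h; on this read-out higher numbers stand for weaker inhibition of growth and lower numbers for stronger inhibition of growth. Compound 1 `CC(C)c1n[nH]c2c(NCc3ccc(-c4ccccn4)cc3)nc(SCCC(N)=O)nc12` gives 120 nM. Compound 3 `CC(C)c1n[nH]c2c(NCc3ccc(-c4ccccn4)cc3)nc(SC(C)C(C)O)nc12` gives 190 nM. Compound 2 `CSc1nc(NCc2ccc(-c3ccccn3)cc2)c2[nH]nc(C(C)C)c2n1` gives 783 nM, the highest of the three numbers; its nearest neighbour is compound 3, and compound 1 lies furthest from it. The step of a 4.1-fold lower number from compound 2 to compound 3 (0.62 log units; beyond the scatter) and the step of a 6.5-fold higher number from compound 1 to compound 2 (0.81 log units; beyond the scatter) both show that exchanging the methyl on the sulfur for a larger group went with a lower number, whereas the step of a 1.6-fold higher number from compound 1 to compound 3 (0.20 log units; within the scatter) between the two larger groups stayed within the scatter.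

Compound 4 `CC(C)c1n[nH]c2c(NCc3ccc(-c4ccccn4)cc3)nc(SC3CCCCC3N)nc12` has not yet been measured. It differs from compound 2 in one place: 2-aminocyclohexyl in place of methyl on a sulfur. The two measured steps that bear on this change are the ones in which the methyl on the sulfur was replaced, and both gave modest lower numbers. The 2-aminocyclohexyl group is yet another replacement of the methyl on the sulfur, so compound 4 is expected to follow the same direction, with a step of about a 3.9-fold lower number from compound 2 to compound 4 (0.59 log units; beyond the scatter) expected. The estimate for compound 4 in this assay is 200 nM, with a range from 90 nM to 450 nM.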

Compound 4, concentration for 50% growth inhibition: 139 nM
Estimate against measurement, compound 4: 1.4-fold (0.16 log units) above, and the stated range covers the measured number.
By their numbers in this assay, from the lowest: compounds 1, 4 and 3 (each within the scatter of the next); then compound 2.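

In this assay the replacement of the methyl on the sulfur by 2-aminocyclohexyl gives a further step in the same direction (a 5.6-fold lower number from compound 2 to compound 4 (0.75 log units; beyond the scatter)), so all three larger groups shown at this place part from compound 2 the same way and none of them goes against this. The entering group brings one six-membered non-aromatic ring of carbon only, yet both a 1.4-fold lower number from compound 3 to compound 4 (0.14 log units; within the scatter) and a 1.2-fold higher number from compound 1 to compound 4 (0.06 log units; within the scatter) lie within the scatter, so a ring group and two open-chain groups cannot be told apart at this place in this read-out. Nothing at hand explains why the larger groups share this result.

The compounds shown leave open whether the step away from methyl depends on the nitrogen of the amine, the hydroxyl or the carbamoyl, or only on carbon added on the sulfur, which a plain cyclohexyl or an unsubstituted propyl chain would separate. They also leave open how a carboxylic acid or a longer chain on the sulfur would read, and whether the two ring carbons bearing the sulfur and the amine matter in one spatial arrangement more than in another.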